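The source may report more compounds than this note shows. Statements on the series, on what has been measured and on what is new or still open speak of the compounds shown alone.

Measured compounds:
compound 1 `NC(=O)c1c(NC(=O)c2cccc([N+](=O)[O-])c2)sc2c1CCN(Cc1ccc(Cl)cc1Cl)C2`, 33000 nM
compound 2 `NC(=O)c1c(NC(=O)c2ccccc2F)sc2c1CCN(C(=O)Nc1ccccc1Cl)C2`, a limit in a functional assay on HeLa cells (Homo sapiens) for antiproliferative activity, with a stated time of 24 h (on this read-out lower numbers stand for stronger inhibition and higher numbers for weaker inhibition), of > 50000 nM

Of the compounds shown here, two share a core and have been tested in this assay. Compound 1 gives 33000 nM. For compound 2 the result is only a limit, > 50000 nM, not a number; this is where compound 2 stands, at the limit of > 50000 nM in this assay, at which 1 of the 2 values shown sits. For the measured compounds named here, the two compounds differ in more than one place, so no single step between them can be read.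

Compound 3 `NC(=O)c1c(NC(=O)c2cccc([N+](=O)[O-])c2)sc2c1CCN(C(=O)Nc1ccccc1Cl)C2` has not been measured. It differs from compound 2 in one place: 3-nitrophenyl in place of 2-fluorophenyl on a carbonyl carbon. Compound 1 also carries a 3-nitrophenyl group on its carbonyl, and its value sits close to the limit at which compound 2 stands, so no large movement in either direction is anticipated. The step from compound 2 to compound 3 in this assay is therefore expected to be an at least 1.1-fold lower number from compound 2 to compound 3 (0.04 log units; that floor lies within the scatter), within the usual scatter. The estimate for compound 3 in this assay is 45000 nM, with a range from 15000 nM to 150000 nM.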

Compound 3, half-maximal inhibitory concentration: > 50000 nM
Compound 3: only a limit was reported (the forecaster's own chance of this, stated with the estimate: 60%); middle value at least 1.1-fold (0.04 log units) away from the limit.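

In this assay compound 3 gives only a limit, > 50000 nM, not a number. On an amine nitrogen in a ring, (2-chlorophenyl)carbamoyl in place of 2,4-dichlorobenzyl gives an at least 1.5-fold higher number from compound 1 to compound 3 (0.18 log units; that floor lies within the scatter), so this change shows no clear shift, since the smallest size the result allows is still within the usual scatter of repeated measurements. The swap of 2-fluorophenyl for 3-nitrophenyl on a carbonyl carbon cannot be read, and with (2-chlorophenyl)carbamoyl on the amine nitrogen, neither of these two groups has yet given a number in this series: the limit of > 50000 nM in this assay, at which 2 of the 3 values shown sit.

As far as these compounds go, whether 2-fluorophenyl and 3-nitrophenyl differ at all on this carbonyl stays open, as does what 2-fluorophenyl would give with 2,4-dichlorobenzyl on the amine nitrogen in the ring. Also open, from the compounds shown here alone, is whether an aminophenyl group on the carbonyl, or a plain benzyl group on that nitrogen, would give a readable number in this assay.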